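The compounds below may be only part of what the source reports. "The series", "measured", "known", "first", "only" and "open" are said of these compounds alone.

Measured compounds:
compound 1, `CC(C(=O)NCc1ccc(C(C)(C)C)cc1N1CCN(c2ccccc2)CC1)c1ccc(NS(C)(=O)=O)c(F)c1`, 0.8 nM
compound 2, `CC(C(=O)NCc1ccc(C(C)(C)C)cc1OC1CCCC1)c1ccc(NS(C)(=O)=O)c(F)c1`, 1.8 nM
compound 3, `CC(C(=O)NCc1ccc(C(C)(C)C)cc1OCc1ccc(F)cc1)c1ccc(NS(C)(=O)=O)c(F)c1`, 3.8 nM

All three values come from an assay on cells for antagonist activity at transient receptor potential cation channel subfamily V member 1 (Homo sapiens), read by FLIPR and calcium flux, with a stated time of 6 min; a higher number here means a weaker inhibitor, a lower number a stronger inhibitor. Compound 3 stands at the high end of the three: against compound 2 the step is a 2.1-fold higher number from compound 2 to compound 3 (0.32 log units; beyond the scatter), and against compound 1 it is a 4.8-fold higher number from compound 1 to compound 3 (0.68 log units; beyond the scatter). Compound 1 to compound 2 gives a 2.3-fold higher number from compound 1 to compound 2 (0.35 log units; beyond the scatter), so within this set the substituent on that aromatic carbon shifts the number by modest amounts only.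

Compound 4 is `CCCCSc1cc(C(C)(C)C)ccc1CNC(=O)C(C)c1ccc(NS(C)(=O)=O)c(F)c1`. Its change from compound 3 is butylsulfanyl in place of (4-fluorobenzyl)oxy on an aromatic carbon, on an aromatic carbon ortho to a large group and meta to a tert-butyl group. The step that bears most directly is a 2.1-fold higher number from compound 2 to compound 3 (0.32 log units; beyond the scatter), where a cyclopentyl in the same position gave the lower number; the step of a 2.3-fold higher number from compound 1 to compound 2 (0.35 log units; beyond the scatter) shows a different kind of group again at a still lower number. Within the data shown here, no measured step holds a sulfur-linked chain, so the direction for butylsulfanyl rests on the observation that the two non-aromatic groups seen so far gave lower numbers than the (4-fluorobenzyl)oxy of compound 3.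

For compound 4 a small step toward a lower number is therefore expected, a 1.3-fold lower number from compound 3 to compound 4 (0.10 log units; within the scatter), possibly within the scatter. The estimate for compound 4 in this assay is 3 nM, with a range from 1 nM to 9 nM.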

Compound 4, inhibition constant: 6.7 nM
Estimate against measurement, compound 4: 2.2-fold (0.35 log units) below, and the stated range covers the measured number.
By their numbers in this assay, from the lowest: compound 1; then compound 2; then compounds 3 and 4 (each within the scatter of the next).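

In this assay, the butylsulfanyl of compound 4, a chain with no ring, stands level with the (4-fluorobenzyl)oxy of compound 3 (a 1.8-fold higher number from compound 3 to compound 4 (0.25 log units; within the scatter)), so a ring in this substituent is not required to stay within the scatter of compound 3. Among these compounds, the earlier reading that groups without an aromatic ring give the lower numbers does not hold across the series: the cyclopentyloxy of compound 2 fits it, but compound 4 goes against it (a 3.7-fold higher number from compound 2 to compound 4 (0.57 log units; beyond the scatter)), and the 4-phenylpiperazin-1-yl of compound 1 remains clearly lower (an 8.4-fold higher number from compound 1 to compound 4 (0.92 log units; beyond the scatter)), which is the widest step at this position so far, though still modest. Nothing on hand accounts for these shifts.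

The compounds shown do not separate the sulfur link from the chain, as no butoxy or cyclopentylsulfanyl group stands among them. As far as these compounds go, it also stays open whether the low number of compound 1 belongs to its ring nitrogen or to its terminal phenyl, a question that a morpholin-4-yl or 4-methylpiperazin-1-yl group at the same position would address.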